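The source may report more compounds than this note shows. Statements on the series, on what has been measured and on what is new or still open speak of the compounds shown alone.

Compound 1 `CC(C)NC(=O)[C@H]1CC[C@@H](n2/c(=N/C(=O)c3ccc(C#N)c(F)c3)[nH]c3ccc(CN4CCC(C(C)(C)O)CC4)cc32)CC1`: 29 mL.min-1.g-1
Compound 2 `CC(C)NC(=O)[C@H]1CC[C@@H](n2/c(=N/C(=O)c3ccc(F)cc3)[nH]c3ccc(CN4CCC[C@H]4C(C)(C)O)cc32)CC1`: 455 mL.min-1.g-1
Compound 3 `CC(C)NC(=O)[C@H]1CC[C@@H](n2/c(=N/C(=O)c3ccccc3)[nH]c3ccc(CN4CCCCC4)cc32)CC1`: 389 mL.min-1.g-1

These numbers come from an in vitro ADME assay on microsomes from liver (Rattus norvegicus) for metabolic stability; a lower number here means slower removal, a higher number faster removal of the compound. Compound 2 stands with compound 3 at the upper end of the three, the two lying within the scatter of each other, while compound 1 lies far lower, beyond the scatter.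

Compound 4 `CC(C)NC(=O)[C@H]1CC[C@@H](n2/c(=N/C(=O)c3ccc(F)cc3)[nH]c3ccc(CN4CC(C(C)(C)O)C4)cc32)CC1` differs from compound 2 in one place: 3-(1-hydroxy-1-methylethyl)azetidin-1-yl in place of 2-(1-hydroxy-1-methylethyl)pyrrolidin-1-yl on a saturated chain carbon bound to an aromatic carbon. The 3-(1-hydroxy-1-methylethyl)azetidin-1-yl group takes the place of 2-(1-hydroxy-1-methylethyl)pyrrolidin-1-yl on a saturated chain carbon bound to an aromatic carbon.

Among the measured compounds shown here, no two measured compounds differ in one place only, so the data show no direct step for this change. Compound 1 also carries a 1-hydroxy-1-methylethyl group and gives 29 mL.min-1.g-1, yet it differs from compound 2 in more than one place, so it offers only weak guidance. For the measured compounds named here, a moderate step downward in this assay is expected, probably beyond the scatter, although no measurement yet supports it directly. The expected step is a 3.0-fold lower number from compound 2 to compound 4 (0.48 log units; beyond the scatter). For compound 4 the estimated value is 150 mL.min-1.g-1, with an expected range of 50 mL.min-1.g-1 to 400 mL.min-1.g-1.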

Compound 4, intrinsic clearance in microsomes: < 14 mL.min-1.g-1
Compound 4: no number, only a limit; the forecaster's own chance of this, stated with the estimate: 3%; middle value at least 10-fold (1.02 log units) away from the limit.
By their numbers in this assay, from the lowest: compound 1; then compounds 3 and 2 (each within the scatter of the next). At a limit, below all of these: compound 4.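

In this assay, putting 3-(1-hydroxy-1-methylethyl)azetidin-1-yl in place of 2-(1-hydroxy-1-methylethyl)pyrrolidin-1-yl on a saturated chain carbon bound to an aromatic carbon gives an at least 32-fold lower number from compound 2 to compound 4 (1.51 log units; beyond the scatter), the only step shown that changes a single place, and it reveals that this position alone can carry a large difference in the number. Both compounds carry the 1-hydroxy-1-methylethyl group, and compound 2 still stands among the highest numbers, which shows that the mere presence of this group does not give a low number. The result for compound 4 is a limit of the assay and not a number: the limit of < 14 mL.min-1.g-1 in this assay, at which 1 of the 4 values shown sits.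

The change alters the ring size, the ring position of the 1-hydroxy-1-methylethyl group and the defined stereocentre all at once, and the compounds shown cannot separate these, nor do they give the full size of the step. Also open, from the compounds shown here alone, is whether the four-membered ring would give a similar result with a methoxy group or a carboxylic acid in place of 1-hydroxy-1-methylethyl.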